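This account rests on a few compounds, and the source may have more. Where it says the series, first, only, none or still open, it means among the compounds named here.

Of the three compounds measured in a functional assay on SMMC-7721 cells (Homo sapiens) for cytotoxicity, read by MTT assay, with a stated time of 4 days (a higher number here means a weaker inhibitor, a lower number a stronger inhibitor), only compound 2 `C=C1C(=O)[C@]23C[C@@]1(O)CC[C@H]2c1ccc(O)c(C)c1[C@@H]3Cn1cc(-c2ccc(C(F)(F)F)cc2)nn1` gives a plain number: compound 2 gives 1440 nM. Compound 1 `C=C1C[C@]23C[C@@]1(O)CC[C@H]2c1ccc(OS(=O)(=O)c2ccc(C)cc2)c(C)c1[C@@H]3Cn1cc(-c2ccccc2)nn1` is reported only as a limit; in this assay compound 1 gives > 20000 nM, a limit of the assay and not a number. Compound 3 `Cc1c(O)ccc2c1[C@H](Cn1cc(-c3ccccn3)nn1)[C@@]13CC(=O)[C@@](C)(CC[C@@H]21)C3` is likewise reported only as a limit, since compound 3 gives > 20000 nM. Two of the three values therefore sit at the limit of > 20000 nM in this assay, at which 2 of the 3 values shown sit, and compound 2 is the only one of the three with a measured value. Among the compounds with values here, no two of the measured compounds differ in one place, so no measured step stands behind the change considered here.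

Compound 4 `C=C1C(=O)[C@]23C[C@@]1(O)CC[C@H]2c1ccc(O)c(C)c1[C@@H]3Cn1cc(-c2ccc(C)cc2)nn1` is the compound yet to be measured. It differs from compound 2 in a single place: methyl in place of trifluoromethyl on an aromatic carbon. With no measured step on such a change among these compounds, the expected step from compound 2 to compound 4 is a 1.7-fold higher number from compound 2 to compound 4 (0.24 log units; within the scatter), small and not clearly beyond the scatter in either direction. Compound 4 is thus estimated at 2500 nM, with a range from 700 nM to 9000 nM.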

Compound 4, half-maximal inhibitory concentration: 920 nM
The estimate for compound 4 lay 2.7-fold (0.43 log units) above the measured number; low and high end bracket the measured number.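

Methyl in place of trifluoromethyl gives, in this assay, a 1.6-fold lower number from compound 2 to compound 4 (0.19 log units; within the scatter), the first step measured among these compounds. At this aromatic carbon, 4-(trifluoromethyl)phenyl and 4-methylphenyl therefore read alike within the scatter, so this single change separates neither compound from the other, and both keep a plain number in this assay. Nothing measured here offers a reason for this result.

The compounds shown leave open whether an amine, a carboxylic acid or a longer chain on this same carbon would also keep a plain number or would move it beyond the scatter. Compound 1 and compound 3 differ from these two in more than one place, so neither of them can settle what this position allows.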